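Iodo in place of fluoro: working notes

This account rests on a few compounds, and the source may have more. Where it says the series, first, only, none or still open, it means among the compounds named here.

compound 1 `CC(=NNC(=S)Nc1cccc([N+](=O)[O-])c1)c1ccccn1`: 69 nM
compound 2 `C/C(=N\NC(=S)Nc1cccc(F)c1)c1ccccn1`: 18 nM
compound 3 `CC(=NNC(=S)Nc1cccc(F)c1)c1ccccn1`: 18 nM

In a functional assay on U-87MG ATCC cells (Homo sapiens) for cytotoxicity, read by MTT assay, with a stated time of 48 h (on this read-out higher numbers stand for weaker inhibition and lower numbers for stronger inhibition), compound 3 gives 18 nM, level with compound 2 at 18 nM, and together they hold the lowest number of the three. Going to compound 4 `CC(=NNC(=S)Nc1cccc(I)c1)c1ccccn1` is iodo in place of fluoro on an aromatic carbon, meta to a large group. For the measured compounds named here, the one measured step at this substituent, a 3.8-fold lower number from compound 1 to compound 3 (0.58 log units; beyond the scatter), swapped nitro for fluoro and was modest. The other, no change at the digits printed from compound 2 to compound 3 (within the scatter), concerns only the drawing of the double bond and gives no guide here. Going by the modest step, the expected change is a 1.4-fold higher number from compound 3 to compound 4 (0.14 log units; within the scatter), not beyond the scatter, with no firm direction. The estimate for compound 4 is 25 nM, with an expected range of 7 nM to 80 nM.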

Compound 4, half-maximal inhibitory concentration: 84 nM
Compound 4: the middle estimate sits 3.4-fold (0.53 log units) below what was measured; the measured number lies above the stated range.
By their numbers in this assay, from the lowest: compounds 2 and 3 (each within the scatter of the next); then compounds 1 and 4 (each within the scatter of the next).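

In this assay, this position separates the two halogens: a 4.7-fold higher number from compound 3 to compound 4 (0.67 log units; beyond the scatter), so the substituent matters here even when one halogen replaces another. Iodo and nitro fall together, a 1.2-fold higher number from compound 1 to compound 4 (0.09 log units; within the scatter), which leaves fluoro alone with the lower number among the three groups seen at this carbon. Nothing available on these compounds bears on the difference between iodo and fluoro.

From the compounds shown here alone, whether the lower number belongs to fluoro alone stays open; chloro, an amine or a carboxylic acid on the same aromatic carbon would test this. Going by these compounds, how these groups behave on the other ring carbons also stays open.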